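Removing a Chloro Group on Two Related Cores

The source may hold more compounds than are shown below. What is called first, only, known or untested is meant among the compounds shown, and "the series" means these compounds.

Four compounds share a methyl-amide pyridine joined through an ether to an anilide, and they were compared in a functional assay on PC-3 cells (Homo sapiens) for cytotoxicity, read by MTT assay, with a stated time of 72 h; a lower number here means a stronger inhibitor, a higher number a weaker inhibitor. Compound 1, `CNC(=O)c1cc(Oc2ccc(NC(=O)c3nccc(-c4ccccc4)n3)cc2)ccn1`, gives 7310 nM in this assay. Compound 2, `CNC(=O)c1cc(Oc2ccc(NC(=O)c3nccc(-c4cccc(Cl)c4)n3)cc2)ccn1`, gives 20800 nM in this assay. The two differ by hydrogen in place of chloro on an aromatic carbon, and that change made a 2.8-fold lower number from compound 2 to compound 1 (0.45 log units; beyond the scatter).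

Compound 3, `CNC(=O)c1cc(Oc2ccc(NC(=O)c3cc(-c4ccc(Cl)cc4)ncn3)cc2)ccn1`, carries the same ether and anilide on a different core. In this assay compound 3 reached only a limit, > 100000 nM, so no number is known for it; it is one of the compounds that sit at the limit of > 100000 nM in this assay, at which 1 of the 3 values shown sits. How the core of compound 3 differs from the core of compound 2 is not broken down here.

Compound 4, `CNC(=O)c1cc(Oc2ccc(NC(=O)c3cc(-c4ccccc4)ncn3)cc2)ccn1`, has not yet been measured. It differs from compound 3 by hydrogen in place of chloro on an aromatic carbon. Going by the values given here, this is the same kind of change as the one from compound 2 to compound 1, though not the same: in the measured pair the chloro sat "meta to a large group", while in compound 3 it sits "para to a large group".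

The step is expected to be an at least 1.4-fold lower number from compound 3 to compound 4 (0.15 log units; that floor lies within the scatter), because the measured pair gave a 2.8-fold lower number from compound 2 to compound 1 (0.45 log units; beyond the scatter). Since compound 3 is known only as a limit, the expected result for compound 4 is 70000 nM, with a likely span from 25000 nM to 200000 nM, and a fair chance that this assay again reports only a limit.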

Compound 4, half-maximal inhibitory concentration: 44200 nM
Compound 4: middle estimate off by 1.6-fold (0.20 log units), on the high side, within the range that was stated.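

In this assay, replacing the 4-chlorophenyl group with phenyl gave an at least 2.2-fold lower number from compound 3 to compound 4 (0.35 log units; beyond the scatter), so hydrogen in place of chloro lowered the number on both cores shown, even though the chloro group sits in a different place on the ring in each pair. On these data alone, compound 3 is known only as a limit, > 100000 nM, which means that this step is a minimum and its true size remains unknown. The direction of the change therefore carried from one core to the other, but two pairs do not establish a general rule, and the sizes of the two steps cannot be ranked: the same change on two cores in this assay, a 2.8-fold lower number (0.45 log units; beyond the scatter) from compound 2 to compound 1 and an at least 2.2-fold lower number (0.35 log units; beyond the scatter) from compound 3 to compound 4; the limit leaves it open whether they differ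

The two pairs differ in both the core and the place of the chloro group, so the compounds shown cannot separate what each of these contributes to the step. They also leave open how this series would respond to other groups at the same spot on the ring, such as a fluoro group, a methoxy group or an amine, since only hydrogen and chloro appear there.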